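The compounds below may be only part of what the source reports. "The series", "measured", "known", "first", "only" and "open" are said of these compounds alone.

Compound 1 `N#Cc1c(N)cccc1Sc1cccc(Cl)c1`: 53000 nM
Compound 2 `N#Cc1cccc(Sc2cccc(N)c2C#N)c1`: 80000 nM

Among the measured compounds shown here, in a functional assay on MT4 cells (Homo sapiens) for cytotoxicity (a lower number here means a stronger inhibitor, a higher number a weaker inhibitor), these two compounds cannot be told apart, because a 1.5-fold higher number from compound 1 to compound 2 (0.18 log units; within the scatter) is the only measured step. Compound 1 therefore has no clear rank and simply sits level with compound 2.

Compound 3 `Cc1cc(Cl)cc(Sc2cccc(N)c2C#N)c1` keeps the core of compound 1 with one change: methyl in place of hydrogen on an aromatic carbon. The new methyl takes the place of a hydrogen, meta to a chloro group. For the measured compounds named here, no measured step tests a methyl. The nearest evidence is the swap of chloro for cyano in compound 2, and that is a different change, seen only once, so it offers weak guidance. No shift beyond the scatter is expected in this assay, in either direction. The expected step is a 1.1-fold lower number from compound 1 to compound 3 (0.03 log units; within the scatter) and counts as no real change. For compound 3 the estimated value is 50000 nM, with a range from 22000 nM to 100000 nM.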

Compound 3, half-maximal inhibitory concentration: 16000 nM
For compound 3 the middle estimate is 3.1-fold (0.49 log units) above the measured one; the measured number lies below the stated range.
By their numbers in this assay, from the lowest: compound 3; then compounds 1 and 2 (each within the scatter of the next).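

Placing a methyl on this aromatic carbon, meta to a chloro group, gives a 3.3-fold lower number from compound 1 to compound 3 (0.52 log units; beyond the scatter) in this assay and this is the first step among these compounds to lie beyond the scatter. This position therefore responds to the addition of a single carbon, although the step is modest, while the swap of chloro for cyano gave only a 1.5-fold higher number from compound 1 to compound 2 (0.18 log units; within the scatter) and left no readable difference. Nothing measured here explains why the methyl has this effect.

On these data alone, it remains open whether the shift is specific to methyl or would also appear with an ethyl, a methoxy group or a fluorine at the same place. It is also unknown whether the methyl would produce a similar step with cyano in place of chloro, as in compound 2.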